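Swapping the pyrazole amide for a benzamide

The source may hold more compounds than are shown below. What is called first, only, known or untested is meant among the compounds shown, and "the series" means these compounds.

Measured compounds:
compound 1 `CC(C)c1cc(C(=O)N2CCc3c(sc(NC(=O)c4ccc(F)cc4)c3C#N)C2)[nH]n1` — "not determined" (no result reported) in a functional assay on Chem-3 cells for antagonist activity at metabotropic glutamate receptor 1 (Homo sapiens), read by fluorescence and calcium flux; on this read-out higher numbers stand for weaker inhibition and lower numbers for stronger inhibition
compound 2 `CC(C)c1cc(C(=O)N2CCc3c(sc(NCc4ccccc4)c3C#N)C2)[nH]n1` — 43200 nM
compound 3 `CC(C)c1cc(C(=O)N2CCc3c(sc(NCc4ccc(F)cc4)c3C#N)C2)[nH]n1` — "not determined" (no result reported)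

Compound 3 stands without a number in this assay, and compound 1 shares that position; only compound 2 carries a value, and in this assay compound 2 gives 43200 nM, which is weak inhibition. Compound 4 `N#Cc1c(NCc2ccc(F)cc2)sc2c1CCN(C(=O)c1ccccc1)C2` differs from compound 3 in one place: phenyl in place of 3-isopropyl-1H-pyrazol-5-yl on a carbonyl carbon. Within the data shown here, no measured pair shows this change, so its direction cannot be read from the data. The expectation is a step within the usual scatter, in no settled direction, around the weak level that compound 2 shows with 43200 nM. Compound 4 is therefore expected to give about 40000 nM in this assay, between 10000 nM and 150000 nM.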

Compound 4, half-maximal inhibitory concentration: 1810 nM
Estimate against measurement, compound 4: 22-fold (1.34 log units) above, and the stated range ends above it.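

Among these compounds, compound 3 stands without a number in this assay, so no step to compound 4 can be read. On these data alone, how (3-isopropyl-1H-pyrazol-5-yl)carbonyl to benzoyl alters inhibition stays open. Nothing at hand explains the result of compound 4.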